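This account rests on a few compounds, and the source may have more. Where it says the series, first, only, none or still open, it means among the compounds named here.

In a functional assay on HepG2 cells (Homo sapiens) for inhibition, read by MTT assay, with a stated time of 72 h (on this read-out lower numbers stand for stronger inhibition and higher numbers for weaker inhibition), compound 3 (`CN1CCN(c2cc(C(=O)N3CCC4(CC3)CC(=O)c3nn(C(C)(C)C)cc3O4)c3ccccc3n2)CC1`) gives 9550 nM, the higher of the two actual numbers. Compound 2 (`CC(C)(C)n1cc2c(n1)C(=O)CC1(CCN(C(=O)c3cc(-c4ccncc4)nc4ccccc34)CC1)O2`) gives 380 nM, the nearest number, and the gap is large (a 25-fold higher number from compound 2 to compound 3 (1.40 log units; beyond the scatter)). Compound 1 (`CC(C)(C)n1cc2c(n1)C(=O)CC1(CCN(C(=O)c3cc(-c4ccccc4Cl)nc4ccccc34)CC1)O2`) reaches only a limit of the assay, > 10000 nM.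

The next change leads to compound 4 (`CC(C)(C)n1cc2c(n1)C(=O)CC1(CCN(C(=O)c3cc(Cl)nc4ccccc34)CC1)O2`), with chloro in place of 4-methylpiperazin-1-yl on an aromatic carbon, next to the ring nitrogen (chloro in place of 4-methylpiperazin-1-yl on an aromatic carbon). The measured steps all exchange groups on this same carbon, though none of them involves chloro. Putting pyridin-4-yl in place of 2-chlorophenyl made a large difference (an at least 26-fold lower number from compound 1 to compound 2 (1.42 log units; beyond the scatter)), whereas 4-methylpiperazin-1-yl in place of 2-chlorophenyl showed none beyond the scatter (an at least 1.0-fold lower number from compound 1 to compound 3 (0.01 log units; that floor lies within the scatter)). Only compound 2 stands apart from the other two, so a large step is not expected here. In this assay the expected step is small, about the size of the scatter, and towards a lower number (a 1.9-fold lower number from compound 3 to compound 4 (0.28 log units; within the scatter)). Compound 4 is estimated at 5000 nM, within an expected range of 1000 nM to 20000 nM.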

Compound 4, half-maximal inhibitory concentration: 4720 nM
Compound 4: the middle estimate sits 1.1-fold (0.03 log units) above what was measured; the measured number falls inside the stated range.
By their numbers in this assay, from the lowest: compound 2; then compound 4; then compound 3. At a limit, above all of these: compound 1.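

On this carbon next to the ring nitrogen, chloro, which brings no ring, gives the first result for a small group, and in this assay it does not fall behind the larger 4-methylpiperazin-1-yl: the change gives a 2.0-fold lower number from compound 3 to compound 4 (0.31 log units; beyond the scatter). Pyridin-4-yl stays clearly apart from it, with a 12-fold higher number from compound 2 to compound 4 (1.09 log units; beyond the scatter), so the low number of compound 2 is not matched by chloro, and compound 2 goes against any reading that a smaller group on this carbon gives the lower number. Against 2-chlorophenyl the change gives an at least 2.1-fold lower number from compound 1 to compound 4 (0.32 log units; beyond the scatter), but that step is only a floor, as compound 1 reaches only a limit of the assay: the limit of > 10000 nM in this assay, at which 1 of the 4 values shown sits.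

As far as these compounds go, it remains open whether the low number of compound 2 depends on the nitrogen of pyridin-4-yl. Phenyl, pyridin-3-yl or a primary amine on this carbon would bear on that question.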